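Aryl variation on the shared core: cytotoxicity working notes

The source may report more compounds than this note shows. Statements on the series, on what has been measured and on what is new or still open speak of the compounds shown alone.

Measured so far:
compound 1, `Cc1ncc([N+](=O)[O-])n1CCSc1nnc(-c2ccc(N)cc2)o1`, 6700 nM
compound 2, `Cc1ncc([N+](=O)[O-])n1CCSc1nnc(-c2ccc(N(C)C)cc2)o1`, 11900 nM
compound 3, `COc1cc(-c2nnc(SCCn3c([N+](=O)[O-])cnc3C)o2)cc(OC)c1OC`, 14900 nM

In a functional assay on HepG2 cells (Homo sapiens) for cytotoxicity, read by MTT assay, with a stated time of 48 h (a higher number here means a weaker inhibitor, a lower number a stronger inhibitor), compound 1 gives 6700 nM, the lowest of the three numbers. Its nearest neighbour is compound 2, reached by a 1.8-fold higher number from compound 1 to compound 2 (0.25 log units; within the scatter). Going by the values given here, compound 3 stands furthest off: compound 1 gives 6700 nM while compound 3 gives 14900 nM, a gap beyond the scatter, though the two structures differ in more than one place and no single step can be drawn between them.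

Compound 4, `Cc1ncc([N+](=O)[O-])n1CCSc1nnc(-c2ccccn2)o1`, awaits measurement in this assay. It differs from compound 1 in one place: pyridin-2-yl in place of 4-aminophenyl on an aromatic carbon. Among the compounds with values here, the only single-place step on the same aromatic ring is that from compound 1 to compound 2, a 1.8-fold higher number from compound 1 to compound 2 (0.25 log units; within the scatter), which stays within the scatter. Within the data shown here, no measured pair exchanges the whole aromatic ring for one with a hetero atom, so the change in compound 4 is not directly anchored. Both departures from compound 1 so far gave higher numbers, one within and one just beyond the scatter, so a small rise is expected, with wide uncertainty.

Compound 4 is therefore estimated at 9500 nM in this assay, with a range from 4000 nM to 22000 nM. The expected step is a 1.4-fold higher number from compound 1 to compound 4 (0.15 log units; within the scatter).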

Compound 4, half-maximal inhibitory concentration: 20200 nM
Compound 4: the middle estimate sits 2.1-fold (0.33 log units) below what was measured; the measured number falls inside the stated range.
By their numbers in this assay, from the lowest: compounds 1, 2, 3 and 4 (each within the scatter of the next, the first and the last beyond it).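

In this assay, going by these compounds alone, pyridin-2-yl in place of 4-aminophenyl on the aromatic carbon of the five-membered ring gives a 3.0-fold higher number from compound 1 to compound 4 (0.48 log units; beyond the scatter) and is the first single-place step from compound 1 printed as beyond the scatter. The earlier change on the same aryl group, a 1.8-fold higher number from compound 1 to compound 2 (0.25 log units; within the scatter), stayed within the scatter, so exchanging the whole aromatic ring registers here where altering the amino group did not separate from the scatter. This exchange removes the hydrogen-bond donor and brings a hetero atom into the six-membered ring at the same time, and no supporting measurement bears on the reason for the step.

The compounds shown do not separate the loss of the amino group from the entry of the ring nitrogen, and a plain phenyl group at this position would give the missing link between compound 1 and compound 4. Going by these compounds, whether the position of the ring nitrogen matters also stays open, as a comparison of pyridin-2-yl with pyridin-3-yl or pyridin-4-yl would be needed to address it.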